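The compounds below may be only part of what the source reports. "The series", "measured", "known", "first", "only" and "open" are said of these compounds alone.

Compound 1 `COCCNc1nnc(SCC(=O)N(Cc2cccc([N+](=O)[O-])c2)c2ccc(F)cc2)s1` and compound 2 `C=CCNc1nnc(SCC(=O)N(Cc2cccc([N+](=O)[O-])c2)c2ccc(F)cc2)s1` share one core and differ only in the group attached to the nitrogen on the aromatic ring. In an assay on isolated protein for inhibition of Amine oxidase [flavin-containing] A (Homo sapiens), read by fluorescence and Amplex Red, with a stated time of 30 min (a lower number here means a stronger inhibitor, a higher number a weaker inhibitor), compound 1 gives 60 nM, while compound 2 gives 502 nM. Among the measured compounds shown here, that difference, an 8.4-fold higher number from compound 1 to compound 2 (0.92 log units; beyond the scatter), is the only step measured so far. On these two numbers compound 2 stands highest, with compound 1 as its nearest neighbour.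

Compound 3 `CC(C)Nc1nnc(SCC(=O)N(Cc2cccc([N+](=O)[O-])c2)c2ccc(F)cc2)s1` carries the next change at the same nitrogen: isopropyl in place of allyl on a nitrogen on an aromatic ring. For the measured compounds named here, no measured step swaps an allyl for an isopropyl, so the only guide is the step from compound 1 to compound 2, which touched the same position with a different pair of groups. The two chains in compound 2 and compound 3 are of equal size, so a step of at most modest size is expected in this assay, with no clear direction. For compound 3 the estimate is 400 nM, within 130 nM to 1200 nM, meaning an expected step of a 1.3-fold lower number from compound 2 to compound 3 (0.10 log units; within the scatter).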

Compound 3, half-maximal inhibitory concentration: 1070 nM
For compound 3 the middle estimate is 2.7-fold (0.43 log units) below the measured one, within the range that was stated.
By their numbers in this assay, from the lowest: compound 1; then compound 2; then compound 3.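

In this assay, isopropyl and allyl have the same count of heavy atoms, yet exchanging them still gives a 2.1-fold higher number from compound 2 to compound 3 (0.33 log units; beyond the scatter), so that count alone does not fix the number at this nitrogen. Among the compounds shown here, the 2-methoxyethyl group of compound 1 now stands apart from both three-carbon groups, with an 18-fold higher number from compound 1 to compound 3 (1.25 log units; beyond the scatter) as the largest step so far, and the three compounds rank 2-methoxyethyl, then allyl, then isopropyl from the lowest number. Nothing available explains this order.

The compounds shown leave open how a straight propyl chain would compare with allyl and isopropyl. They also leave open whether 2-hydroxyethyl or the longer 3-methoxypropyl would keep a number as low as that of compound 1.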